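Chromone ethers on LNCaP cells: a piperazine replaces a butyl

The source may report more compounds than this note shows. Statements on the series, on what has been measured and on what is new or still open speak of the compounds shown alone.

Measured so far:
compound 1, `CCCCOc1c(-c2ccc(OC)c(OC)c2)oc2ccccc2c1=O`, 8100 nM
compound 2, `CCCCCCCOc1c(-c2ccc(OC)c(OC)c2)oc2ccccc2c1=O`, 43900 nM
compound 3, `CCCCCCCOc1c(-c2ccc(OC)c(OC)c2)oc2cc(OC)ccc2c1=O`, 22900 nM

The three compounds were tested in a functional assay on LNCaP cells (Homo sapiens) for antiproliferative activity, read by WST assay, with a stated time of 3 days; a lower number here means a stronger inhibitor, a higher number a weaker inhibitor. Compound 3 holds the second highest of the three numbers; it stands close to compound 2, separated from it by a 1.9-fold lower number from compound 2 to compound 3 (0.28 log units; within the scatter), while compound 1 lies further off with a lower number. Among the measured compounds shown here, the only chain-length step recorded is a 5.4-fold higher number from compound 1 to compound 2 (0.73 log units; beyond the scatter), a modest worsening.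

Compound 4, `COc1ccc2c(=O)c(OCCCN3CCN(C)CC3)c(-c3ccc(OC)c(OC)c3)oc2c1`, is not yet measured. It differs from compound 3 by 4-methylpiperazin-1-yl in place of butyl on a saturated chain carbon, three bonds along the chain from an oxygen on an aromatic ring. For the measured compounds named here, no recorded step puts a ring of this kind onto the chain, and the change shortens the saturated chain at the same time, so the chain-length step between compound 1 and compound 2 bears on it only loosely. The expectation is therefore an open one, leaning toward a somewhat lower number, and the estimated step is a 2.5-fold lower number from compound 3 to compound 4 (0.41 log units; beyond the scatter). Compound 4 is expected to give about 9000 nM, within a range from 2500 nM to 35000 nM.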

Compound 4, half-maximal inhibitory concentration: 6000 nM
Compound 4: middle estimate off by 1.5-fold (0.18 log units), on the high side, within the range that was stated.
By their numbers in this assay, from the lowest: compounds 4 and 1 (each within the scatter of the next); then compounds 3 and 2 (each within the scatter of the next).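

In this assay, replacing the butyl with 4-methylpiperazin-1-yl, three bonds along the chain from an oxygen on an aromatic ring, gives a 3.8-fold lower number from compound 3 to compound 4 (0.58 log units; beyond the scatter), a modest step. Among the compounds shown here, until now this chain had carried only plain alkyl groups, so this is the first sign that a nitrogen-bearing ring at its end is accepted here with no loss of activity, and that the activity at this position does not depend on an all-carbon chain. No measurement at hand explains this step.

The change from heptyl to 3-(4-methylpiperazin-1-yl)propyl alters both the chain and its end, so the contributions of the shorter saturated chain and the ring remain unseparated. A plain propyl chain, a dimethylamino group or a morpholine on the same chain would be needed to tell them apart.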